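Changing the Group on the Ring Nitrogen of Compound 3

A few compounds are considered here, and "the series" means these few. Any claim that something is new, unique, unknown or untested is made for them only; others in the source may bear on it.

In a physicochemical assay for lipophilicity, read by HPLC, measured as chromatographic lipophilicity, at pH 7.4 (on this read-out lower numbers stand for lower lipophilicity and higher numbers for higher lipophilicity), compound 1 `O=C(C1CCN(c2ncccn2)CC1)N1N=CC[C@H]1c1ccccc1` gives 4.7, compound 2 `O=C(c1cnco1)N1CCC(C(=O)N2N=CC[C@H]2c2ccccc2)CC1` gives 2.7 and compound 3 `O=C(C1CCN(c2ccncn2)CC1)N1N=CC[C@H]1c1ccccc1` gives 3.2, the middle of the three numbers. Compound 4 `Cc1nnc(N2CCC(C(=O)N3N=CC[C@H]3c3ccccc3)CC2)o1` differs from compound 3 in one place: 5-methyl-1,3,4-oxadiazol-2-yl in place of pyrimidin-4-yl on an amine nitrogen in a ring, with 5-methyl-1,3,4-oxadiazol-2-yl in place of pyrimidin-4-yl on an amine nitrogen in a ring. Swaps on this same nitrogen have already given a number 2.00 log units lower from compound 1 to compound 2 (beyond the scatter), then a number 1.50 log units lower from compound 1 to compound 3 (beyond the scatter), and also a number 0.50 log units higher from compound 2 to compound 3 (beyond the scatter). None of them brings in the new group, so the direction remains uncertain. A modest fall is expected in this assay, namely a number 0.50 log units lower from compound 3 to compound 4 (beyond the scatter). Compound 4 is estimated at 2.7, with an expected range of 2.2 to 3.3.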

Compound 4, distribution coefficient: 3.2
For compound 4 the middle estimate is 0.50 log units below the measured one, within the range that was stated.
By their numbers in this assay, from the lowest: compound 2; then compounds 3 and 4 (each within the scatter of the next); then compound 1.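

Putting 5-methyl-1,3,4-oxadiazol-2-yl on the amine nitrogen gives no change at the digits printed from compound 3 to compound 4 (within the scatter) in this assay even though a five-membered aromatic ring with 3 hetero atoms replaces a six-membered one with 2 hetero atoms. The new group also gives a number 0.50 log units higher from compound 2 to compound 4 (beyond the scatter) and a number 1.50 log units lower from compound 1 to compound 4 (beyond the scatter) so two different aromatic rings now read alike here while pyrimidin-2-yl stays apart. Nothing measured here explains these numbers.

Still open, on these data alone, is where an acetyl group or a pyridine ring carrying an amine would fall on this nitrogen. The compounds also leave open how the same oxadiazole ring would read without its methyl.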